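From Thiophene to Benzothiophene on the Shared Core

The source may hold more compounds than are shown below. What is called first, only, known or untested is meant among the compounds shown, and "the series" means these compounds.

Three analogues with a common core differ only in the aromatic group attached to it. Compound 1 `CCOC(=O)c1cnc(-c2ccncc2)nc1NN1C(=O)C=C(C)C1=O` gives 6000 nM in a functional assay on Jurkat cells for inhibition of nuclear factor NF-kappa-B complex (Homo sapiens); a lower number here means a stronger inhibitor, a higher number a weaker inhibitor. Compound 2 `CCOC(=O)c1cnc(-c2cccc(Br)c2)nc1NN1C(=O)C=C(C)C1=O` gives 700 nM in this assay, and compound 3 `CCOC(=O)c1cnc(-c2ccsc2)nc1NN1C(=O)C=C(C)C1=O` gives 100 nM in this assay. Compound 3 therefore has the lowest number of the three: the step of a 60-fold lower number from compound 1 to compound 3 (1.78 log units; beyond the scatter) is the widest, the step of a 7.0-fold lower number from compound 2 to compound 3 (0.85 log units; beyond the scatter) is narrower, and both lie beyond the scatter. The step of an 8.6-fold lower number from compound 1 to compound 2 (0.93 log units; beyond the scatter) shows that swapping the aromatic group alone moves the number by a modest amount.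

Compound 4 `CCOC(=O)c1cnc(-c2cc3ccccc3s2)nc1NN1C(=O)C=C(C)C1=O` is not yet measured. It differs from compound 3 by 1-benzothiophen-2-yl in place of thiophen-3-yl on an aromatic carbon. Within the data shown here, none of the measured steps adds a six-membered aromatic ring of carbon only to a group that worked well, so the only precedent is that the aromatic group matters a great deal in this assay. A step of a 2.5-fold higher number from compound 3 to compound 4 (0.40 log units; beyond the scatter) is expected, a mild loss with wide uncertainty. Compound 4 is estimated at 250 nM, within a range from 50 nM to 1500 nM.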

Compound 4, half-maximal inhibitory concentration: 4000 nM
Compound 4: the middle estimate sits 16-fold (1.20 log units) below what was measured, and the stated range ends below it.
By their numbers in this assay, from the lowest: compound 3; then compound 2; then compounds 4 and 1 (each within the scatter of the next).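

Adding a six-membered aromatic ring of carbon only to the sulfur-containing ring is costly in this assay, where 1-benzothiophen-2-yl gives a 40-fold higher number from compound 3 to compound 4 (1.60 log units; beyond the scatter) and so loses the advantage seen with thiophen-3-yl. The new group also trails 3-bromophenyl, with a 5.7-fold higher number from compound 2 to compound 4 (0.76 log units; beyond the scatter), and stands level with pyridin-4-yl, with a 1.5-fold lower number from compound 1 to compound 4 (0.18 log units; within the scatter), so at this carbon between two ring nitrogen atoms, a sulfur-containing five-membered aromatic ring does not by itself secure a low number. Nothing measured on these compounds accounts for the loss.

The change both adds a ring and moves the attachment point on the sulfur-containing ring, and thiophen-2-yl, which carries no added ring, would help separate the two. Going by these compounds, how a methyl group or an amine on thiophen-3-yl would behave also remains open.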